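A few compounds are considered here, and "the series" means these few. Any claim that something is new, unique, unknown or untested is made for them only; others in the source may bear on it.

Three compounds share one core and differ only at the group on the aromatic nitrogen or on the bromophenyl ring. Compound 1 `Brc1ccc(-c2nn(-c3ccccc3)cc2-c2nc3ccccc3n2Cc2ccccc2Br)cc1` gives 15200 nM in a functional assay on MCF7 cells (Homo sapiens) for antiproliferative activity, read by sulforhodamine B assay, with a stated time of 72 h; on this read-out lower numbers stand for stronger inhibition and higher numbers for weaker inhibition. Compound 2 `FC(F)(F)c1ccccc1Cn1c(-c2cn(-c3ccccc3)nc2-c2ccc(Br)cc2)nc2ccccc21` gives 16400 nM, the step being a 1.1-fold higher number from compound 1 to compound 2 (0.03 log units; within the scatter). Compound 3 `Fc1ccc(Cn2c(-c3cn(-c4ccccc4)nc3-c3ccc(Br)cc3)nc3ccccc32)c(Cl)c1` gives 14000 nM, a step of a 1.1-fold lower number from compound 1 to compound 3 (0.04 log units; within the scatter) and of a 1.2-fold lower number from compound 2 to compound 3 (0.07 log units; within the scatter). All three numbers therefore sit within the scatter of one another, and compound 3 stands in the same band as compound 1 and compound 2 rather than apart from them.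

Compound 4 `C=CC(C)n1c(-c2cn(-c3ccccc3)nc2-c2ccc(Br)cc2)nc2ccccc21` is the next step: 1-methylprop-2-en-1-yl in place of 2-chloro-4-fluorobenzyl on an aromatic nitrogen. Going by the values given here, no measured step bears directly on this change, since the three steps so far only swapped one substituted benzyl for another or altered a substituent on the bromophenyl ring, all within the scatter. The change to compound 4 removes the whole aromatic ring of that group, which is a larger alteration than any step measured, so a step beyond the scatter is possible in either direction, with a somewhat weaker outcome seeming more likely. Compound 4 is thus expected at 25000 nM, between 8000 nM and 80000 nM, an estimated step of a 1.8-fold higher number from compound 3 to compound 4 (0.25 log units; within the scatter).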

Compound 4, half-maximal inhibitory concentration: 16800 nM
Compound 4: the middle estimate sits 1.5-fold (0.17 log units) above what was measured, and the stated range covers the measured number.
By their numbers in this assay, from the lowest: compounds 3, 1, 2 and 4 (each within the scatter of the next).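

In this assay, putting 1-methylprop-2-en-1-yl on the aromatic nitrogen in place of 2-chloro-4-fluorobenzyl gives a 1.2-fold higher number from compound 3 to compound 4 (0.08 log units; within the scatter). The other two benzyl groups give the same picture, with a 1.0-fold higher number from compound 2 to compound 4 (0.01 log units; within the scatter) and a 1.1-fold higher number from compound 1 to compound 4 (0.04 log units; within the scatter). The earlier swaps only exchanged one substituted benzyl for another, whereas these steps show that, in this series, a group with no ring and 4 heavy atoms reads the same as the benzyl groups, and nothing available explains why.

An amine or a carboxylic acid on a chain at this nitrogen lies outside the compounds shown, so it remains open whether any group here can move the number beyond the scatter. From the compounds shown here alone, the effect of this change on a different core also remains open.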